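The compounds below may be only part of what the source reports. "The series", "measured", "known", "first", "only" and "open" are said of these compounds alone.

Measured in a functional assay on CHO cells with adenosine receptor A1 (Homo sapiens) as the target, read by cAMP accumulation and immunoassay, with a stated time of 6 min, tested at 1 uM; a higher number here means a weaker effect of the compound at the concentration tested, a lower number a stronger effect:
- compound 1, `Nc1scc(CN2CCN(c3cc(Cl)cc(Cl)c3)CC2)c1C(=O)c1ccc(Cl)cc1`: -69%
- compound 2, `Nc1scc(CN2CCN(c3c(F)cccc3F)CC2)c1C(=O)c1ccc(Cl)cc1`: -65%

Compound 2 stands with the highest of the two numbers, but its nearest neighbour, compound 1, sits within the scatter of it, so the two are not separated. Within the data shown here, the one step available on this series, a number 4 percentage points higher from compound 1 to compound 2 (within the scatter), is a swap of the aryl group on the ring nitrogen, and it stays within the scatter.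

Compound 3, `Nc1scc(CN2CCN(c3ccccc3Cl)CC2)c1C(=O)c1ccc(Cl)cc1`, is the next variation at the same site: 2-chlorophenyl in place of 2,6-difluorophenyl on an amine nitrogen in a ring. This is again an aryl-for-aryl exchange on the amine nitrogen in the ring, of the same kind as the step from compound 1 to compound 2. That step gives the only bearing here, and it was flat. No step beyond the scatter is therefore expected in this assay for compound 3; the estimated step is a number 3 percentage points higher from compound 2 to compound 3 (within the scatter). Compound 3 is expected to give -62%, within -82% to -38%.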

Compound 3, a percentage reported as activity, at one concentration (the size of the read-out at that concentration, not a potency): -5.2%
The estimate for compound 3 lay 56.8 percentage points below the measured number; the measured number lies above the stated range.
By their numbers in this assay, from the lowest: compounds 1 and 2 (each within the scatter of the next); then compound 3.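

In this assay, the aryl group on the amine nitrogen in the ring is not a silent site: the flat exchange between 3,5-dichlorophenyl and 2,6-difluorophenyl does not extend to 2-chlorophenyl, with a number 59.8 percentage points higher from compound 2 to compound 3 (beyond the scatter) and a number 63.8 percentage points higher from compound 1 to compound 3 (beyond the scatter), both towards a weaker effect at the concentration tested. Two different aryl groups that read alike therefore gave no safe guide to a third, and this site separates aryl groups sharply within the three compounds shown. Nothing available bears on the reason for this drop.

The compounds shown leave open whether the drop follows from the loss of the second halogen or from which halogen is present. A 2,6-dichlorophenyl group and a phenyl group with no substituent, on the same core, would help to separate these two readings.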